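Swapping bromo for chloro in a growth inhibitor

The compounds below may be only part of what the source reports. "The series", "measured", "known", "first", "only" and "open" are said of these compounds alone.

In a functional assay on DU-145 cells (Homo sapiens) for inhibition, read by trypan blue exclusion, with a stated time of 96 h (a higher number here means a weaker inhibitor of growth, a lower number a stronger inhibitor of growth), three compounds have been measured so far:

- compound 1 `O=C(/C(=C\c1ccc(Br)cc1)SCc1ccc(Cl)cc1)c1ccc(Br)cc1` gives 1000 nM
- compound 2 `O=C(/C(=C\c1ccc(O)cc1)SCc1ccc(Cl)cc1)c1ccc(Br)cc1` gives 10000 nM
- compound 3 `O=C(/C(=C\c1ccc(Br)cc1)Sc1ccc(Br)cc1)c1ccc(Br)cc1` gives 1000 nM

Compound 1 shares the lowest of these three numbers with compound 3, while compound 2 has the highest. The next compound, compound 4 `O=C(/C(=C\c1ccc(Br)cc1)SCc1ccc(Cl)cc1)c1ccc(Cl)cc1`, differs from compound 1 by a single swap (chloro in place of bromo on an aromatic carbon). The swap sits on an aromatic carbon of a six-membered aromatic ring of carbon only, para to a large group, and it turns (4-bromophenyl)carbonyl into (4-chlorophenyl)carbonyl.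

Among the compounds with values here, two measured steps bear on this. Hydroxy in place of bromo on an aromatic carbon gave a clear step (a 10-fold higher number from compound 1 to compound 2 (1.00 log units; beyond the scatter)). Putting 4-bromophenyl in place of 4-chlorobenzyl on a sulfur gave none (no change at the digits printed from compound 1 to compound 3 (within the scatter)). Neither step touched the (4-bromophenyl)carbonyl group, and no measurement tests this swap directly. The new swap exchanges one halogen for another, unlike the hydroxy of compound 2, and no step beyond the scatter is expected in this assay for it. The estimated step is no change at the digits printed from compound 1 to compound 4 (within the scatter) in this read-out. Compound 4 is estimated at 1000 nM with an expected range between 400 nM and 3000 nM in this assay.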

Compound 4, concentration for 50% growth inhibition: 1000 nM
For compound 4 middle estimate and measured number coincide at the digits printed; the measured number falls inside the stated range.
By their numbers in this assay, from the lowest: compounds 1, 3 and 4 (each within the scatter of the next); then compound 2.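

In this assay, the step of no change at the digits printed from compound 1 to compound 4 (within the scatter) is the only one shown that alters the (4-bromophenyl)carbonyl group, so it gives the first direct reading at this place on the molecule. At this aromatic carbon, chloro can stand in for bromo with the result staying within the scatter, which means that 4-chlorophenyl and 4-bromophenyl cannot be told apart in this read-out. The larger step of a 10-fold higher number from compound 1 to compound 2 (1.00 log units; beyond the scatter) came from hydroxy replacing bromo at a different aromatic carbon, so it says nothing about how this place responds to a group other than a halogen, and no independent measurement is available to explain why the two halogens read alike here.

Going by these compounds, it remains open what an amine, a carboxylic acid or a hydroxy would do at this same carbon, and whether fluoro would also read like chloro and bromo. Also open, on these data alone, is whether chloro in place of bromo on the other bromo-bearing aromatic ring of compound 1 would likewise stay within the scatter.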